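Cyclopropane carbohydrazides: trifluoroethoxy to ethoxy on the aryl ether

The source may hold more compounds than are shown below. What is called first, only, known or untested is meant among the compounds shown, and "the series" means these compounds.

Measured so far in a functional assay on PC-3 cells (Homo sapiens) for inhibition, read by MTT assay, with a stated time of 72 h; a lower number here means a stronger inhibitor, a higher number a weaker inhibitor:
compound 1 `O=C(NNC(=O)C1CC1c1ccc(OC(F)(F)F)cc1)c1ccncc1` — > 100000 nM (a limit)
compound 2 `CCOc1ccc(C2CC2C(=O)NNC(=O)c2ccncc2)cc1` — > 100000 nM (a limit)
compound 3 `O=C(NNc1nncc2ccccc12)C1CC1c1ccc(OCC(F)(F)F)cc1` — 67000 nM

Within the data shown here, compound 3 gives the only numerical value in this assay; the other two values are limits. For compound 1 the value in this assay is a limit, (the limit of > 100000 nM in this assay, at which 2 of the 3 values shown sit). The change to compound 4 `CCOc1ccc(C2CC2C(=O)NNc2nncc3ccccc23)cc1` is methyl in place of trifluoromethyl on a saturated chain carbon bound to an oxygen on an aromatic ring. Among the measured compounds shown here, the one measured step, a step that the two limits leave unreadable from compound 1 to compound 2, concerns the same oxygen but a different group and its size cannot be read from two limits, so no measured step bears on the present change. No shift beyond the scatter is therefore expected for compound 4 in this assay, and a result reported only as a limit is plausible. Compound 4 is estimated at 85000 nM (range 30000 nM to 250000 nM), an expected step of a 1.3-fold higher number from compound 3 to compound 4 (0.10 log units; within the scatter).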

Compound 4, half-maximal inhibitory concentration: 94000 nM
The estimate for compound 4 lay 1.1-fold (0.04 log units) below the measured number; the measured number falls inside the stated range.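

In this assay, among these compounds, the change from 2,2,2-trifluoroethoxy to ethoxy on the shared core gives the first readable step at this aryl ether: a 1.4-fold higher number from compound 3 to compound 4 (0.15 log units; within the scatter). For this one pair, trifluoromethyl can give way to methyl without a shift beyond the scatter. The remaining values give no such reading: the limit of > 100000 nM in this assay, at which 2 of the 4 values shown sit.

Still open, on these data alone, is whether a longer chain, such as propoxy, or an amine-bearing chain in place of ethoxy would move the number beyond the scatter. Also open, as far as these compounds go, is whether the same change would read alike on the core carrying the limits.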